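Nitro for Hydroxy, Repeated on a Second Core

The source may hold more compounds than are shown below. What is called first, only, known or untested is meant among the compounds shown, and "the series" means these compounds.

Compound 1 `COc1cc(OC)c2sc(-c3ccc(N/C=C\C(=O)c4ccc(OC)c(O)c4)c(C)c3)nc2c1` gives 14300 nM in a functional assay on A549 cells (Homo sapiens) for antiproliferative activity, read by sulforhodamine B assay, with a stated time of 48 h; a higher number here means a weaker inhibitor, a lower number a stronger inhibitor. Compound 2 `COc1cc(OC)c2sc(-c3ccc(N/C=C\C(=O)c4ccc(OC)c([N+](=O)[O-])c4)c(C)c3)nc2c1` carries nitro in place of hydroxy on an aromatic carbon and gives 12100 nM in this assay, a step of a 1.2-fold lower number from compound 1 to compound 2 (0.07 log units; within the scatter). Compound 3 `COc1ccc(C(=O)/C=C\Nc2ccc(-c3nc4cc(OC)c(OC)c(OC)c4s3)cc2)cc1O` rests on a different core; the difference between the two cores is not broken down here. In this assay compound 3 gives 23000 nM. Among the measured compounds shown here, compound 4 `COc1ccc(C(=O)/C=C\Nc2ccc(-c3nc4cc(OC)c(OC)c(OC)c4s3)cc2)cc1[N+](=O)[O-]` arises from compound 3 by nitro in place of hydroxy on an aromatic carbon, the same change as the one separating compound 1 and compound 2, with the same surroundings at the place. Because the step of a 1.2-fold lower number from compound 1 to compound 2 (0.07 log units; within the scatter) stayed within the scatter, a step of similar size is expected for compound 4. The expected step is a 1.2-fold lower number from compound 3 to compound 4 (0.07 log units; within the scatter). Compound 4 is estimated at 19500 nM in this assay, between 9000 nM and 42000 nM.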

Compound 4, half-maximal inhibitory concentration: 21200 nM
Compound 4: middle estimate off by 1.1-fold (0.04 log units), on the low side; measured number inside the range.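

Nitro in place of hydroxy gives, in this assay, a step of a 1.1-fold lower number from compound 3 to compound 4 (0.04 log units; within the scatter) on the core of compound 3. Set beside the earlier step, the change carries from one core to the other with no difference that can be told apart: the same change on two cores in this assay, a 1.2-fold lower number (0.07 log units; within the scatter) from compound 1 to compound 2 and a 1.1-fold lower number (0.04 log units; within the scatter) from compound 3 to compound 4, 1.1-fold (0.04 log units) apart, within the scatter of two such steps. Among the compounds shown here, this shows only that the exchange leaves the number within the scatter on these two cores; two pairs do not show that the same would hold on any other core, or that a step beyond the scatter would carry over in the same way.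

The compounds shown leave open whether an amine or a carboxylic acid on that aromatic carbon would give a step of similar size. They also leave open what a longer chain in place of the methoxy group would do.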